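This account rests on a few compounds, and the source may have more. Where it says the series, first, only, none or still open, it means among the compounds named here.

In an assay on Cerebral cortex for displacement of a labelled ligand from adenosine receptor A1 (Bos taurus) (on this read-out lower numbers stand for stronger inhibition and higher numbers for weaker inhibition), compound 3 `Clc1ccccc1Cn1nnc2c(NC3CCCC3)nc(-c3ccccc3)nc21` gives 9 nM, the lowest of the three numbers shown. Compound 1 `CNc1nc(-c2ccccc2)nc2c1nnn2Cc1ccccc1Cl` gives 191 nM and compound 2 `CCNc1nc(-c2ccccc2)nc2c1nnn2Cc1ccccc1Cl` gives 463 nM. The steps of a 21-fold lower number from compound 1 to compound 3 (1.33 log units; beyond the scatter) and a 51-fold lower number from compound 2 to compound 3 (1.71 log units; beyond the scatter) both lead to compound 3, whereas a 2.4-fold higher number from compound 1 to compound 2 (0.38 log units; beyond the scatter) is modest. Compound 4 `Clc1ccccc1Cn1nnc2c(NC3CCCCC3)nc(-c3ccccc3)nc21` differs from compound 3 by cyclohexyl in place of cyclopentyl on a nitrogen on an aromatic ring. Going by the values given here, no measured step compares these two rings directly; the steps that bear on it show large drops when cyclopentyl replaces methyl or ethyl, but say nothing about the six-membered ring. The step from compound 3 to compound 4 is therefore expected to be small, a 1.7-fold higher number from compound 3 to compound 4 (0.22 log units; within the scatter), possibly within the scatter. Compound 4 is estimated at 15 nM, with a range from 4 nM to 50 nM.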

Compound 4, inhibition constant: 34 nM
The estimate for compound 4 lay 2.3-fold (0.36 log units) below the measured number; the measured number falls inside the stated range.
By their numbers in this assay, from the lowest: compound 3; then compound 4; then compound 1; then compound 2.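

In this assay, going by these compounds alone, this is the only direct comparison of two rings on this nitrogen, and a 3.8-fold higher number from compound 3 to compound 4 (0.58 log units; beyond the scatter) shows that cyclohexyl does not simply match cyclopentyl. Cyclohexyl still stands apart from the smaller open groups, with a 5.6-fold lower number from compound 1 to compound 4 (0.75 log units; beyond the scatter) and a 14-fold lower number from compound 2 to compound 4 (1.13 log units; beyond the scatter) as the steps from methyl and ethyl. Nothing available explains the difference between the two rings. The compounds shown leave open how cyclobutyl, cycloheptyl or a branched chain such as isopropyl would compare on this nitrogen.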